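Fluorine on the pyridyl nitrogen substituent: Vero cytotoxicity outlook

This account rests on a few compounds, and the source may have more. Where it says the series, first, only, none or still open, it means among the compounds named here.

The series shares one core carrying a carboxylic acid and a furan-linked exocyclic alkene; the compounds differ only in the aryl group on the ring nitrogen. Compound 1 is `O=C(O)c1cccc(-c2ccc(/C=C3\S/C(=N\c4ccc(Cl)cc4)N(c4ccc(Cl)cc4)C3=O)o2)c1`. In an ADME assay on Vero cells (Chlorocebus sabaeus) for cytotoxicity (a lower number here means that less compound is tolerated, a higher number that more compound is tolerated), compound 1 reaches only the limit of > 200000 nM. Compound 2 is `O=C(O)c1cccc(-c2ccc(/C=C3\S/C(=N\c4ccc(Cl)cc4)N(c4ccccc4)C3=O)o2)c1`. In this assay compound 2 likewise returns only the limit of > 200000 nM. Compound 3 is `O=C(O)c1cccc(-c2ccc(/C=C3\S/C(=N\c4ccc(Cl)cc4)N(c4ccccn4)C3=O)o2)c1`. In this assay compound 3 again gives only the limit of > 200000 nM.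

Accordingly every step between measured compounds is unreadable: a step that the two limits leave unreadable from compound 1 to compound 2, a step that the two limits leave unreadable from compound 1 to compound 3 and a step that the two limits leave unreadable from compound 2 to compound 3. The reason is the limit of > 200000 nM in this assay, at which 3 of the 3 values shown sit, so compound 3 stands at the limit together with the two others, with no number to rank it.

Compound 4 is `O=C(O)c1cccc(-c2ccc(/C=C3\S/C(=N\c4ccc(Cl)cc4)N(c4ncccc4F)C3=O)o2)c1`. It differs from compound 3 by fluoro in place of hydrogen on an aromatic carbon, read one bond further out as pyridin-2-yl to 3-fluoropyridin-2-yl. Going by the values given here, none of the measured steps carries information about size, since all end at the limit; a single fluorine is a smaller change than any of them. The expectation for compound 4 is therefore no readable step, a step that the limit leaves unreadable from compound 3 to compound 4, in this assay. Compound 4 is estimated to remain at the limit, with a central value of 250000 nM and a range from 100000 nM to 600000 nM.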

Compound 4, half-maximal cytotoxic concentration: > 200000 nM
Compound 4: a limit, no number; the forecaster's own chance of this, stated with the estimate: 85%; the middle value does not contradict the limit.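

In this assay no step can be read from compound 1, compound 2 or compound 3 to compound 4, because all four compounds end at a limit and not at a number: the limit of > 200000 nM in this assay, at which 4 of the 4 values shown sit. The compounds shown leave open whether the aryl groups on the ring nitrogen differ at all in this assay, and by how much.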